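The source may hold more compounds than are shown below. What is called first, only, known or untested is meant among the compounds shown, and "the series" means these compounds.

In a functional assay on cells for antagonist activity at C-X-C chemokine receptor type 4 (Homo sapiens), read by fluorescence and calcium flux, with stated times of 25 min and 90 s (on this read-out lower numbers stand for stronger inhibition and higher numbers for weaker inhibition), the three measured compounds give these numbers:

Compound 1 `c1ccc2c(c1)CN[C@@H](CN(CCCCNCC1CCSCC1)[C@H]1CCCc3cccnc31)C2`: 69.6 nM
Compound 2 `O=S1(=O)CCC(NCCCCN(C[C@H]2Cc3ccccc3CN2)[C@H]2CCCc3cccnc32)CC1`: 45.5 nM
Compound 3 `CC1(C)CCC(NCCCCN(C[C@H]2Cc3ccccc3CN2)[C@H]2CCCc3cccnc32)CC1`: 77.6 nM

Compound 3 gives the highest of the three numbers, but its separation from the others is small: a 1.1-fold higher number from compound 1 to compound 3 (0.05 log units; within the scatter) and a 1.7-fold higher number from compound 2 to compound 3 (0.23 log units; within the scatter). The three compounds therefore cannot be ordered on these data.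

Compound 4 `CC(C)(CCN(C[C@H]1Cc2ccccc2CN1)[C@H]1CCCc2cccnc21)CNCC1CCOCC1` has not yet been measured. Relative to compound 3 the change is a group of 12 heavy atoms (10 carbon, 1 nitrogen, 1 oxygen; one six-membered non-aromatic ring with 1 hetero atom) in place of a group of 11 heavy atoms (10 carbon, 1 nitrogen; one six-membered non-aromatic ring of carbon only), on a saturated chain carbon, two bonds along the chain from an amine nitrogen. The measured steps all concern exchanges of the group on an amine nitrogen, and none of them moved beyond the scatter: a 1.5-fold lower number from compound 1 to compound 2 (0.18 log units; within the scatter), a 1.1-fold higher number from compound 1 to compound 3 (0.05 log units; within the scatter), a 1.7-fold higher number from compound 2 to compound 3 (0.23 log units; within the scatter). The step to compound 4 also alters the saturated chain itself, for which no measured comparison exists, so the uncertainty is wider than for the measured exchanges. On the evidence available, the expected step is a 1.1-fold higher number from compound 3 to compound 4 (0.04 log units; within the scatter), that is, no shift beyond the scatter in this assay. Compound 4 is therefore estimated at 85 nM, with a range from 30 nM to 250 nM.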

Compound 4, half-maximal inhibitory concentration: 43.8 nM
For compound 4 the middle estimate is 1.9-fold (0.29 log units) above the measured one, and the stated range covers the measured number.
By their numbers in this assay, from the lowest: compounds 4, 2, 1 and 3 (each within the scatter of the next).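

In this assay, the change on a saturated chain carbon, two bonds along the chain from an amine nitrogen, stays within the scatter against each earlier compound (a 1.8-fold lower number from compound 3 to compound 4 (0.25 log units; within the scatter); a 1.0-fold lower number from compound 2 to compound 4 (0.02 log units; within the scatter); a 1.6-fold lower number from compound 1 to compound 4 (0.20 log units; within the scatter)). The earlier steps shown here covered only exchanges of the group on an amine nitrogen, whereas these show that a group of 12 heavy atoms with one six-membered non-aromatic ring with 1 hetero atom can stand at this place with no shift beyond the scatter. Nothing available accounts for this result.

The share of the chain alteration and the share of the ring group in these steps cannot be separated on the compounds shown. Also open, from the compounds shown here alone, is whether a carboxylic acid or a longer chain at this place would stay within the scatter.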